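A few compounds are considered here, and "the series" means these few. Any claim that something is new, unique, unknown or untested is made for them only; others in the source may bear on it.

Compound 1 `Cc1cccc(CSc2cc(Cl)c(C)cc2S(=O)(=O)/N=C(\N)n2nccc2-c2ccccc2)c1` gives 6500 nM.
Compound 2 `Cc1cc(-c2ccccc2)n(/C(N)=N/S(=O)(=O)c2cc(C)c(Cl)cc2SCc2cccc3ccccc23)n1` gives 7000 nM.

Both numbers come from a functional assay on HCT-116 cells (Homo sapiens) for cytotoxicity, read by MTT assay, with a stated time of 72 h; on this read-out higher numbers stand for weaker inhibition and lower numbers for stronger inhibition. Compound 2 has the higher of the two numbers, but compound 1 sits within the scatter of it, so the two cannot be told apart. Compound 3 `Cc1ccc(CSc2cc(Cl)c(C)cc2S(=O)(=O)/N=C(\N)n2nc(C)cc2-c2ccccc2)cc1` is not yet measured; it differs from compound 2 in one place: 4-methylphenyl in place of naphthalen-1-yl on a saturated chain carbon bound to a sulfur. Compound 1, which carries a different group on a saturated chain carbon bound to a sulfur, gives 6500 nM, within the scatter of compound 2, so only a small step is expected here, with no direction beyond the scatter. Compound 3 is expected to give about 6500 nM, between 2500 nM and 17000 nM. That estimate means an expected 1.1-fold lower number from compound 2 to compound 3 (0.03 log units; within the scatter).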

Compound 3, half-maximal inhibitory concentration: 28000 nM
Estimate against measurement, compound 3: 4.3-fold (0.63 log units) below, and the stated range ends below it.
By their numbers in this assay, from the lowest: compounds 1 and 2 (each within the scatter of the next); then compound 3.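

Replacing naphthalen-1-yl with 4-methylphenyl on a saturated chain carbon bound to a sulfur gives a 4.0-fold higher number from compound 2 to compound 3 (0.60 log units; beyond the scatter) in this assay, so weaker inhibition. This shows that the group at this place can change the result beyond the scatter, which the first two compounds could not show, as they differ in more than one place. Nothing measured here gives a reason for this step. Still open, on these data alone, is whether an unsubstituted phenyl, a naphthalen-2-yl or a carboxylic acid at this place would read closer to compound 2 or compound 3.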